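From Ethyl to Propyl on the Carbonyl Chain

A few compounds are considered here, and "the series" means these few. Any claim that something is new, unique, unknown or untested is made for them only; others in the source may bear on it.

In a functional assay on A549 cells (Homo sapiens) for inhibition, with a stated time of 48 h, tested at 50 uM (a higher number here means more inhibition of growth at the concentration tested, a lower number less inhibition of growth), compound 1 `C=C[C@@](C)(/C=C/c1ccc(OC(C)=O)cc1)CCC=C(C)C` gives 72%. For the measured compounds named here, compound 2 `C=C[C@@](C)(/C=C/c1ccc(OC(=O)CC)cc1)CCC=C(C)C` gives 42%, the lower of the two numbers known so far. Going by the values given here, the only measured step is a number 30 percentage points lower from compound 1 to compound 2 (beyond the scatter), and it accompanies methyl in place of hydrogen on a saturated chain carbon bound to a carbonyl carbon.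

Compound 3 `C=C[C@@](C)(/C=C/c1ccc(OC(=O)CCC)cc1)CCC=C(C)C` has not yet been measured. It differs from compound 2 by methyl in place of hydrogen on a saturated chain carbon, two bonds along the chain from a carbonyl carbon, which puts methyl in place of hydrogen on a saturated chain carbon, two bonds along the chain from a carbonyl carbon, so that ethyl becomes propyl. The change is of the same kind as the measured one but lies further along the chain. Among the compounds with values here, that single step from compound 1 to compound 2, a number 30 percentage points lower from compound 1 to compound 2 (beyond the scatter), is the only guide, and one step establishes no trend. A further fall is therefore expected, though a smaller one, and it may not clearly exceed the scatter. The expected change is a number 11 percentage points lower from compound 2 to compound 3 (beyond the scatter). For compound 3 the estimated value is 31%, with an expected range from 11% to 50%.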

Compound 3, percent growth inhibition at one concentration: 50%
Compound 3: the middle estimate sits 19 percentage points below what was measured, and the stated range covers the measured number.
By their numbers in this assay, from the lowest: compounds 2 and 3 (each within the scatter of the next); then compound 1.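

In this assay, methyl in place of hydrogen on a saturated chain carbon, two bonds along the chain from a carbonyl carbon, gives a number 8 percentage points higher from compound 2 to compound 3 (within the scatter), so in this read-out ethyl and propyl cannot be told apart, and the loss that came with the first added methyl does not continue with the second. The two added methyl groups taken together still leave a number 22 percentage points lower from compound 1 to compound 3 (beyond the scatter), which means that compound 1 stands clear of both compound 2 and compound 3, and that among these three the clear difference lies only between compound 1 and the other two. Nothing at hand bears on why the effect of the added carbon differs between these two places on the chain.

From the compounds shown here alone, whether a longer chain such as butyl would stay level with compound 2 and compound 3 or would differ from them remains open, as does the outcome for a branched chain. An amine or a carboxylic acid carried on the propyl chain is equally untested among the compounds shown, and a single tested concentration leaves any fuller comparison of these compounds unsettled.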